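The compounds below may be only part of what the source reports. "The series", "measured", "known", "first", "only" and "open" are said of these compounds alone.

Measured so far in a physicochemical assay for solubility, read by HPLC, in phosphate buffer, with a stated time of 24 h, at pH 7.4, tested at 100 uM; on this read-out higher numbers stand for higher solubility and lower numbers for lower solubility

Compound 1 `O=C(CCCCCNc1c(Nc2ccccc2)c(=O)c1=O)NO` gives 47000000 nM
Compound 2 `O=C(CCCCNc1c(Nc2ccccc2)c(=O)c1=O)NO` gives 87000000 nM
Compound 3 `O=C(CCCCCNc1c(NCc2ccccc2)c(=O)c1=O)NO` gives 75000000 nM

Compound 3 does not stand apart on these numbers. Its value lies within the usual scatter of both compound 1 and compound 2, so the three cannot be put in a firm order. The next compound, compound 4 `CC[C@H](Nc1c(NCCCCCC(=O)NO)c(=O)c1=O)c1ccccc1`, has not yet been measured. It differs from compound 3 by ethyl in place of hydrogen on a saturated chain carbon bound to an aromatic carbon and a nitrogen on an aromatic ring which means ethyl in place of hydrogen on a saturated chain carbon bound to an aromatic carbon and a nitrogen on an aromatic ring.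

Going by the values given here, two measured steps bear on this change, although neither touches that carbon. Benzyl in place of phenyl gives a 1.6-fold higher number from compound 1 to compound 3 (0.20 log units; within the scatter) and hydroxycarbamoyl in place of (hydroxycarbamoyl)methyl gives a 1.9-fold higher number from compound 1 to compound 2 (0.27 log units; within the scatter) so both stay small. Among the compounds with values here, no measured compound tests a group added at this carbon, which leaves the direction unsettled. A slightly lower number is the cautious expectation. In this assay the expected result is a 1.5-fold lower number from compound 3 to compound 4 (0.18 log units; within the scatter) and no step beyond the scatter is anticipated. For compound 4 the estimated value is 50000000 nM within an expected range from 20000000 nM to 90000000 nM until a measurement settles it.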

Compound 4, solubility: 75000000 nM
Compound 4: the middle estimate sits 1.5-fold (0.18 log units) below what was measured, and the stated range covers the measured number.
By their numbers in this assay, from the lowest: compounds 1, 3, 4 and 2 (each within the scatter of the next).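

In this assay, putting ethyl in place of hydrogen on a saturated chain carbon bound to an aromatic carbon and a nitrogen on an aromatic ring gives no change at the digits printed from compound 3 to compound 4 (within the scatter), and this step is the only direct reading at this carbon among the compounds shown. The earlier steps shown here changed the chain bearing the hydroxycarbamoyl group or swapped phenyl for benzyl, so they could only hint at this position, whereas this step shows that an added group of two carbon atoms, with no ring and no hydrogen-bond donors or acceptors, leaves the number within the scatter here. Nothing measured in this set gives a reason for this result.

Going by these compounds alone, whether an amine, a carboxylic acid or a longer chain at this same carbon would also stay within the scatter remains open, since ethyl is the only group read at this position. Also open, as far as these compounds go, is whether the opposite spatial arrangement at this carbon would give a similar number, as would the same ethyl group combined with the chain of compound 2.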